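The compounds below may be only part of what the source reports. "The series", "measured", "known", "first", "only" and "open" are said of these compounds alone.

Measured compounds:
compound 1, `Cc1cccc(NC(=O)N[C@H](C)c2ccccc2)c1`, 47%
compound 2, `CCc1ccccc1NC(=O)N[C@H](C)c1ccccc1`, 92%
compound 3, `CCc1cccc(NC(=O)N[C@H](C)c2ccccc2)c1`, 36%

All three share a urea that links two aromatic parts. In an ADME assay on the whole organism with Oryza sativa as the target, tested at 10 uM (a higher number here means a weaker effect of the compound at the concentration tested, a lower number a stronger effect), compound 1 gives 47%, and compound 3 gives 36%. These two differ in a single place, namely (methyl in place of hydrogen on a saturated chain carbon bound to an aromatic carbon), and that change brought a number 11 percentage points lower from compound 1 to compound 3 (beyond the scatter). Compound 2, which gives 92% in this assay, stands apart: its number is the highest of the three, and its gaps to compound 1 and to compound 3 are both beyond the scatter, so among these three it has the weakest effect. The difference between the core of compound 2 and the core of compound 1 is not broken down here.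

Compound 4, `CC(C)c1ccccc1NC(=O)N[C@H](C)c1ccccc1`, has not yet been measured. It is related to compound 2 by methyl in place of hydrogen on a saturated chain carbon bound to an aromatic carbon and a saturated chain carbon. Going by the values given here, this is the same kind of change as the one from compound 1 to compound 3, but not the same: there the entering group sat on a saturated chain carbon bound to an aromatic carbon, here it sits on a saturated chain carbon bound to an aromatic carbon and a saturated chain carbon. Because the earlier change gave a number 11 percentage points lower from compound 1 to compound 3 (beyond the scatter), a step of a similar modest size is expected from compound 2 to compound 4, a number 11 percentage points lower from compound 2 to compound 4 (beyond the scatter). Compound 4 is therefore estimated to give 81% in this assay, with a likely range from 62% to 96%.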

Compound 4, a percentage reported as activity, at one concentration (the size of the read-out at that concentration, not a potency): 17%
Compound 4: the middle estimate sits 64 percentage points above what was measured; the measured number lies below the stated range.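

In this assay, the change from ethyl to isopropyl brings a number 75 percentage points lower from compound 2 to compound 4 (beyond the scatter), which makes compound 4 much stronger in its effect at the concentration tested than compound 2. Adding a methyl in place of a hydrogen lowers the number on both cores, but the size of the step does not carry over from one to the other, as the two steps show: the same change on two cores in this assay, a number 11 percentage points lower (beyond the scatter) from compound 1 to compound 3 and a number 75 percentage points lower (beyond the scatter) from compound 2 to compound 4, 64 percentage points apart, beyond the scatter of two such steps. Going by these compounds alone, this does not show why the steps differ, since there are only two pairs and they differ both in the core and in the carbon that receives the methyl, so the gap cannot be assigned to either difference alone.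

The compounds shown leave open what the same ethyl to isopropyl change would do on the core of compound 3, and so whether the large step belongs to that change itself or to the core of compound 2. They also leave open whether a tert-butyl group in place of the isopropyl would lower the number further, and whether a methoxy group in its place would give a number like that of compound 4.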